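The source may hold more compounds than are shown below. What is called first, only, known or untested is meant among the compounds shown, and "the series" means these compounds.

Going by the values given here, in a physicochemical assay for solubility, read by HPLC, at pH 7.4 (on this read-out lower numbers stand for lower solubility and higher numbers for higher solubility), compound 3 `COc1cc2[nH]c(C)c(C)c(=O)c2cc1Cl` gives 5000 nM, the only actual number in this small set. Compound 1 `Cc1[nH]c2ccccc2c(=O)c1/C=C/c1cccc([N+](=O)[O-])c1` gives only a limit, < 2000 nM. Compound 2 `CCCCCCCCCc1c(C)[nH]c2cc(OC)c(Cl)cc2c1=O` also gives only a limit, < 2000 nM. Compound 4 `C=C(CCCCC)c1c(C)[nH]c2cc(OC)c(Cl)cc2c1=O` keeps the core of compound 3 but carries a larger group in place of the methyl on an aromatic carbon: a group of 7 heavy atoms (7 carbon; no ring) in place of one carbon atom, on an aromatic carbon. The nearest measured change is an at least 2.5-fold higher number from compound 2 to compound 3 (0.39 log units; beyond the scatter), with hydrogen in place of octyl on a saturated chain carbon, and it is beyond the scatter. Its true size is open, given (the limit of < 2000 nM in this assay, at which 2 of the 3 values shown sit). Read in reverse, it points to a lower number in this assay on adding the longer chain. The expected change is a 3.3-fold lower number from compound 3 to compound 4 (0.52 log units; beyond the scatter). Compound 4 is estimated at 1500 nM, with an expected range of 500 nM to 4000 nM.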

Compound 4, solubility: 2000 nM
The estimate for compound 4 lay 1.3-fold (0.12 log units) below the measured number; the measured number falls inside the stated range.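

In this assay, the group of 7 heavy atoms in place of the methyl on this aromatic carbon gives a 2.5-fold lower number from compound 3 to compound 4 (0.40 log units; beyond the scatter). Both ends of this step are actual numbers, so the change has a definite size. Compound 2 gives only a limit, < 2000 nM, so its step to compound 3 has no definite size.

As far as these compounds go, whether an ethyl group, an amine or a carboxylic acid on this aromatic carbon would raise or lower the number stays open. A longer chain here might return only a limit: the limit of < 2000 nM in this assay, at which 2 of the 4 values shown sit.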